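From 4-bromophenyl to 3-iodophenyl on a carbonyl carbon

A few compounds are considered here, and "the series" means these few. Any claim that something is new, unique, unknown or untested is made for them only; others in the source may bear on it.

Measured values in a functional assay on HepG2 cells (Homo sapiens) for inhibition, read by MTT assay (on this read-out lower numbers stand for stronger inhibition and higher numbers for weaker inhibition), are these
Compound 1 `COc1cc2ncnc(Nc3ccc(NC(=O)c4cccc(C)c4)cc3)c2cc1OC` gives 7500 nM
Compound 2 `COc1cc2ncnc(Nc3ccc(NC(=O)c4ccccc4F)cc3)c2cc1OC` gives 13000 nM
Compound 3 `COc1cc2ncnc(Nc3ccc(NC(=O)c4ccc(Br)cc4)cc3)c2cc1OC` gives 35000 nM

Compound 3 stands highest of the three and is the weakest, with both of its steps beyond the scatter (a 2.7-fold higher number from compound 2 to compound 3 (0.43 log units; beyond the scatter)) and (a 4.7-fold higher number from compound 1 to compound 3 (0.67 log units; beyond the scatter)). Compound 4 `COc1cc2ncnc(Nc3ccc(NC(=O)c4cccc(I)c4)cc3)c2cc1OC` has yet to be measured in this assay and carries 3-iodophenyl in place of 4-bromophenyl on a carbonyl carbon. Among the measured compounds shown here, no measured compound carries iodine, so the closest guide is compound 1 with its 3-methylphenyl group. The modest step (a 4.7-fold higher number from compound 1 to compound 3 (0.67 log units; beyond the scatter)) is the measured change that bears most directly, and it suggests that leaving 4-bromophenyl could lower the number. The step (a 1.7-fold higher number from compound 1 to compound 2 (0.24 log units; within the scatter)) lies within the scatter and adds no direction. A modest step toward a lower number is therefore expected (a 2.9-fold lower number from compound 3 to compound 4 (0.46 log units; beyond the scatter)). For compound 4 the estimated value is 12000 nM with an expected range from 5000 nM to 30000 nM in this assay.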

Compound 4, half-maximal inhibitory concentration: 28000 nM
For compound 4 the middle estimate is 2.3-fold (0.37 log units) below the measured one, and the stated range covers the measured number.
By their numbers in this assay, from the lowest: compounds 1 and 2 (each within the scatter of the next); then compounds 4 and 3 (each within the scatter of the next).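

In this assay, exchanging 4-bromophenyl for 3-iodophenyl on the carbonyl carbon leaves the two compounds within the scatter of each other (a 1.3-fold lower number from compound 3 to compound 4 (0.10 log units; within the scatter)), so this change does not bring the number down towards that of compound 1. The 3-iodophenyl group also separates compound 4 from the other two, with a 2.2-fold higher number from compound 2 to compound 4 (0.33 log units; beyond the scatter) and, for iodo in place of methyl on an aromatic carbon, a 3.7-fold higher number from compound 1 to compound 4 (0.57 log units; beyond the scatter), so compound 4 does not share the lower number of the 3-methylphenyl compound. Nothing available explains these differences.

The step from compound 3 to compound 4 changes the halogen and its place on the phenyl ring together, so the compounds shown cannot separate those two changes. From the compounds shown here alone, how an amine or a carboxylic acid on this phenyl ring would read also remains open.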